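A few compounds are considered here, and "the series" means these few. Any claim that something is new, unique, unknown or untested is made for them only; others in the source may bear on it.

Compound 1 `CC(C)(C)NC(=O)COC(=O)c1ccc([N+](=O)[O-])o1` sits at the upper edge of what an ADME assay on MT4 cells (Homo sapiens) for cytotoxicity, read by MTT assay, with a stated time of 3 days (on this read-out higher numbers stand for lower toxicity in this test and lower numbers for higher toxicity in this test), can report. In this assay compound 1 gives > 100000 nM, which is a limit and not a number. Compound 3 `CC(C)(C)N(Cc1ccc(F)cc1)C(=O)COC(=O)c1ccc([N+](=O)[O-])o1` gives > 100000 nM, also a limit. Compound 2 `CC(C)(C)N(CCCc1ccccc1)C(=O)COC(=O)c1ccc([N+](=O)[O-])o1` is recorded as "not active" (no number reported). The picture so far is the limit of > 100000 nM in this assay, at which 2 of the 3 values shown sit.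

Compound 4 `CC(=O)COC(=O)c1ccc([N+](=O)[O-])o1` changes the core of compound 1 at one place: methyl in place of (tert-butyl)amino on a carbonyl carbon. The (tert-butyl)amino group is thus replaced by methyl on a carbonyl carbon.

Among the measured compounds shown here, only one measured step offers any guide, a step that the two limits leave unreadable from compound 1 to compound 3, and it gives no size. It also keeps the amide-type nitrogen that compound 4 loses, so it bears only loosely on this change. No readable step therefore supports a large move in this assay, and a modest shift toward lower numbers is allowed for as a precaution. The step expected is an at least 1.2-fold lower number from compound 1 to compound 4 (0.09 log units; that floor lies within the scatter). For compound 4 the estimated value is 80000 nM, with an expected range from 20000 nM to 200000 nM.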

Compound 4, half-maximal cytotoxic concentration: > 100000 nM
Compound 4: no number, only a limit (the forecaster's own chance of this, stated with the estimate: 60%); middle value at least 1.2-fold (0.09 log units) from the limit.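

Compound 1 and compound 4 both stand at a limit in this assay, and the step between them cannot be read. The compounds shown leave open what number any of them would give, and whether methyl in place of (tert-butyl)amino on a carbonyl carbon changes it at all.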